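This account rests on a few compounds, and the source may have more. Where it says the series, first, only, none or still open, it means among the compounds named here.

Of the compounds shown here, two built on the same core have so far been measured in a functional assay on NCI/ADR-RES cells (Homo sapiens) for inhibition, read by sulforhodamine B assay, with a stated time of 48 h; on this read-out lower numbers stand for stronger inhibition of growth and higher numbers for weaker inhibition of growth. Compound 1 `CCOC(=O)C1=C(C)NC(=S)NC1c1cc(OC)c(O)c(OC)c1` gives 25 ug/mL in this assay, the higher of the two numbers seen so far. Compound 2 `CCOC(=O)C1=C(C)NC(=O)NC1c1ccc(O)c(O)c1` gives 2.1 ug/mL in this assay, a far lower number, and the gap between these two compounds lies beyond the usual scatter of the measurement.

Compound 3 `CCOC(=O)C1=C(C)NC(=S)NC1c1ccc(O)c(OC)c1` has not yet been measured. It differs from compound 1 in a single place: hydrogen in place of methoxy on an aromatic carbon. Going by the values given here, no measured pair isolates the effect of such a change, since compound 2 differs from compound 1 in more than one place at once. On that basis only a small shift is expected, toward stronger growth inhibition, and the step of a 1.7-fold lower number from compound 1 to compound 3 (0.22 log units; within the scatter) is expected to stay close to the edge of the scatter. Compound 3 is expected to give about 15 ug/mL in this assay, within a range from 5 ug/mL to 40 ug/mL.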

Compound 3, concentration for 50% growth inhibition: 59.7 ug/mL
Compound 3: the middle estimate sits 4.0-fold (0.60 log units) below what was measured; the measured number lies above the stated range.
By their numbers in this assay, from the lowest: compound 2; then compound 1; then compound 3.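

In this assay, putting hydrogen in place of the methoxy group on the aromatic carbon ortho to a hydroxy group gives a 2.4-fold higher number from compound 1 to compound 3 (0.38 log units; beyond the scatter) and this modest step lies beyond the scatter. Going by these compounds alone, it is the first comparison here between compounds that differ in one place only, and it shows that growth inhibition becomes weaker, not stronger, when this methoxy group is lost from compound 1. Nothing measured here explains why the number rises.

The compounds shown leave open whether another group on this carbon, such as an ethoxy group, a fluorine atom or an amine, would match or improve on methoxy. Within the data shown here, no single-place pair connects compound 2 to the others, so the source of its much lower number cannot yet be traced to any one difference in structure.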